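The source may report more compounds than this note shows. Statements on the series, on what has been measured and on what is new or still open speak of the compounds shown alone.

Three compounds with a shared core were examined in a functional assay on HSC-4 cells (Homo sapiens) for cytotoxicity, read by MTT assay, with a stated time of 48 h (a lower number here means that less compound is tolerated, a higher number that more compound is tolerated), and a fourth awaits measurement. Compound 2 `O=C1/C(=C/c2ccccc2)CN(C(=O)CCSCCO)C/C1=C\c1ccccc1` carries a (2-hydroxyethyl)sulfanyl chain on its amide, and in this assay compound 2 gives 1530 nM. Compound 1 `O=C1/C(=C/c2ccccc2)CN(C(=O)CCSCCS(=O)(=O)O)C/C1=C\c1ccccc1` differs from it by one change, (sulfo in place of hydroxy on a saturated chain carbon, two bonds along the chain from a sulfur), and compound 1 gives 154000 nM. That single change produced a 100-fold higher number from compound 2 to compound 1 (2.00 log units; beyond the scatter), so the sulfo compound is tolerated far more than the hydroxy one.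

Compound 3 `O=C1/C(=C/c2ccc([N+](=O)[O-])cc2)CN(C(=O)CCSCCO)C/C1=C\c1ccc([N+](=O)[O-])cc1` keeps the hydroxy chain of compound 2 but differs from it in the core; the difference between the two cores is not broken down here. In this assay compound 3 gives 390 nM, the lowest of the three numbers, with compound 2 nearest and compound 1 furthest.

Compound 4 `O=C1/C(=C/c2ccc([N+](=O)[O-])cc2)CN(C(=O)CCSCCS(=O)(=O)O)C/C1=C\c1ccc([N+](=O)[O-])cc1` stands to compound 3 as compound 1 stands to compound 2: it carries sulfo in place of hydroxy on a saturated chain carbon, two bonds along the chain from a sulfur, and the place of the change is the same in both pairs. Setting the expected step beside the measured one, the account rests on compound 3 at 390 nM and on a 100-fold higher number from compound 2 to compound 1 (2.00 log units; beyond the scatter), so the step from compound 3 to compound 4 is estimated as a 100-fold higher number from compound 3 to compound 4 (2.00 log units; beyond the scatter). Compound 4 is therefore expected to give about 39000 nM in this assay, most likely between 8000 nM and 200000 nM.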

Compound 4, half-maximal cytotoxic concentration: 4730 nM
Compound 4: middle estimate off by 8.2-fold (0.92 log units), on the high side; the measured number lies below the stated range.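

In this assay, sulfo in place of hydroxy on a saturated chain carbon, two bonds along the chain from a sulfur, again gives a higher number on the second core, with a 12-fold higher number from compound 3 to compound 4 (1.08 log units; beyond the scatter), so the direction of the change carries over from one core to the other in these two pairs. The size of the change does not carry over, and the two steps cannot be treated as one transferable increment: the same change on two cores in this assay, a 100-fold higher number (2.00 log units; beyond the scatter) from compound 2 to compound 1 and a 12-fold higher number (1.08 log units; beyond the scatter) from compound 3 to compound 4, 8.3-fold (0.92 log units) apart, beyond the scatter of two such steps These two pairs do not show which part of the difference between the cores goes with the smaller step, and they give no basis for stating the size of the step on a third core.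

The compounds shown leave open whether a carboxylic acid or an amine in place of the sulfo group, or a longer chain carrying it, would give a step of similar size on either core. They also leave open how the step would behave on a core with chloro or methoxy groups in place of the nitro groups, which would help to show whether its size follows the substituents on the core.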